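The source may hold more compounds than are shown below. What is called first, only, known or untested is meant among the compounds shown, and "the series" means these compounds.

Working notes on the coumarin-type series bearing the 3-chlorobenzyloxy group; all four members share that core and differ only in the group opposite the ring oxygen.

Compound 1 `CCOc1cc(=O)oc2cc(OCc3cccc(Cl)c3)ccc12` gives 115 nM in an assay on isolated protein (strain Sprague-Dawley) for inhibition of Amine oxidase [flavin-containing] B (Rattus norvegicus), read by spectrophotometry, with a stated time of 5 min; on this read-out higher numbers stand for weaker inhibition and lower numbers for stronger inhibition. Compound 2 `NC(=O)COc1cc(=O)oc2cc(OCc3cccc(Cl)c3)ccc12` gives 3.1 nM; 3.31 nM (2 entries) in this assay; the two entries of compound 2 agree with each other (the several entries of compound 2 in this assay, 3.1 nM; 3.31 nM (2 entries)). Among the measured compounds shown here, compound 3 `CN(C)C(=O)COc1cc(=O)oc2cc(OCc3cccc(Cl)c3)ccc12` gives 501 nM in this assay, the highest of the two single numbers in the set; the only measured step that reaches it is a 4.4-fold higher number from compound 1 to compound 3 (0.64 log units; beyond the scatter). For the measured compounds named here, compound 2 sits well below both compound 1 and compound 3 on the bare values, but no single step to either of them is on hand, so only the numbers themselves are noted.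

Compound 4 `CNc1cc(=O)oc2cc(OCc3cccc(Cl)c3)ccc12` has not yet been measured in this assay. It differs from compound 3 by methylamino in place of (dimethylcarbamoyl)methoxy on an aromatic carbon. The measured step from compound 1 to compound 3 ran in the direction of weaker inhibition as the group at that carbon grew; the present change removes that group entirely and puts a small donor-bearing substituent in its place. On that basis compound 4 is expected to fall below compound 3 in this assay, with the estimated step of a 3.3-fold lower number from compound 3 to compound 4 (0.52 log units; beyond the scatter). The estimate for compound 4 is 150 nM, with a range from 30 nM to 800 nM.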

Compound 4, half-maximal inhibitory concentration: 8.71 nM
For compound 4 the middle estimate is 17-fold (1.24 log units) above the measured one; measured number outside the range, below it.
By their numbers in this assay, from the lowest: compound 4; then compound 1; then compound 3.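

In this assay, the aromatic carbon opposite the ring oxygen tolerates more than an oxygen-linked group, and the change to a nitrogen-linked one moves the number a long way. Methylamino in place of (dimethylcarbamoyl)methoxy gives a 58-fold lower number from compound 3 to compound 4 (1.76 log units; beyond the scatter), and methylamino in place of ethoxy gives a 13-fold lower number from compound 1 to compound 4 (1.12 log units; beyond the scatter), so the drop appears against both the larger and the smaller of these two oxygen-linked groups, whereas the earlier step kept the oxygen and only changed what it carried. The measurements on hand offer no explanation for the size of either step.

Compound 4 alone carries a nitrogen at this carbon, so the compounds shown cannot separate the contribution of that nitrogen from that of its methyl group; the unsubstituted amine and dimethylamino at the same carbon would bear directly on this. Also open, on these data alone, is whether ethylamino or a longer chain on that nitrogen, or a carbamoylmethyl group like the one on the oxygen of compound 2, would hold the number near that of compound 4 at 8.71 nM.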